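This account rests on a few compounds, and the source may have more. Where it says the series, first, only, none or still open, it means among the compounds named here.

Measured compounds:
compound 1, `CCCCOC(=O)c1cccc(-c2cc(C(=O)Nc3ccncc3)ccc2CN)c1`: 5.5 nM
compound 2, `CCCCCCOC(=O)c1cccc(-c2cc(C(=O)Nc3ccncc3)ccc2CN)c1`: 22 nM
compound 3, `NCc1ccc(C(=O)Nc2ccncc2)cc1-c1cccc(C(=O)OCc2ccccc2)c1`: 45 nM

In an assay on isolated protein for inhibition of Rho-associated protein kinase 2 (Homo sapiens), read by radiometric assay (a higher number here means a weaker inhibitor, a lower number a stronger inhibitor), compound 3 gives the highest number of the three measured esters. Its nearest neighbour is compound 2, and the gap between them is a 2.0-fold higher number from compound 2 to compound 3 (0.31 log units; beyond the scatter); the widest gap is to compound 1, an 8.2-fold higher number from compound 1 to compound 3 (0.91 log units; beyond the scatter). Compound 4, `CCCCCOC(=O)c1cccc(-c2cc(C(=O)Nc3ccncc3)ccc2CN)c1`, has not yet been tested. The change from compound 3 to compound 4 is butyl in place of phenyl on a saturated chain carbon bound to an oxygen next to a carbonyl group. Among the measured compounds shown here, two measured steps bear on it directly, both running the opposite way: an 8.2-fold higher number from compound 1 to compound 3 (0.91 log units; beyond the scatter) and a 2.0-fold higher number from compound 2 to compound 3 (0.31 log units; beyond the scatter). The chain that enters in compound 4 sits between the chains of compound 1 and compound 2 in length, and the step of a 4.0-fold higher number from compound 1 to compound 2 (0.60 log units; beyond the scatter) shows how those two differ. A lower number than compound 3 is therefore expected for compound 4, by a modest amount, estimated as a 3.8-fold lower number from compound 3 to compound 4 (0.57 log units; beyond the scatter). The estimate for compound 4 in this assay is 12 nM, with a range of 5 nM to 30 nM.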

Compound 4, half-maximal inhibitory concentration: 4.9 nM
Beside the measured number, compound 4's estimate is 2.4-fold (0.39 log units) above it; the whole stated range lies above it.
By their numbers in this assay, from the lowest: compounds 4 and 1 (each within the scatter of the next); then compound 2; then compound 3.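

In this assay the change from benzyloxycarbonyl to pentyloxycarbonyl gives a 9.2-fold lower number from compound 3 to compound 4 (0.96 log units; beyond the scatter) and so shows that, among these esters, the benzyl group carries a clear cost against a pentyl chain of this kind. The earlier compounds shown here showed only that hexyl gave a higher number than butyl, whereas the step to pentyl, a 1.1-fold lower number from compound 1 to compound 4 (0.05 log units; within the scatter) and so no readable change, together with a 4.5-fold lower number from compound 2 to compound 4 (0.65 log units; beyond the scatter) places that rise at the final extension to the hexyl chain of compound 2. Nothing available here accounts for either difference.

From the compounds shown here alone, whether a propyl chain would keep the number of compound 1 and compound 4 remains open. So does the outcome with a cyclohexylmethyl ester, which would test the benzyl ring against a saturated one, or with a carboxylic acid or an amide in place of the ester.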